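Methoxy for Fluoro Across Two Related Cores

This account rests on a few compounds, and the source may have more. Where it says the series, first, only, none or still open, it means among the compounds named here.

Compound 1 `O=C(COc1c(-c2ccccc2)oc2ccccc2c1=O)Nc1ccc(F)cc1` carries a (4-fluorophenyl)amino group on its ether side chain, and in a functional assay on NPC-TW01 cells (Homo sapiens) for antiproliferative activity, read by MTT assay, with a stated time of 72 h (a lower number here means a stronger inhibitor of growth, a higher number a weaker inhibitor of growth), compound 1 gives 9500 nM. Compound 2 `COc1ccc(NC(=O)COc2c(-c3ccccc3)oc3ccccc3c2=O)cc1` differs from it in one place only, (methoxy in place of fluoro on an aromatic carbon), and in this assay compound 2 gives 5480 nM. The measured step, a 1.7-fold lower number from compound 1 to compound 2 (0.24 log units; within the scatter), is therefore too small to count as a real change in growth inhibition between these two compounds.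

Compound 3 `O=C(COc1ccc2c(=O)cc(-c3ccccc3)oc2c1)Nc1ccc(F)cc1` is built from the same atoms as compound 1, joined differently; the difference between the two cores is not broken down here. In this assay compound 3 reaches only a limit, > 10000 nM. That is the limit of > 10000 nM in this assay, at which 1 of the 3 values shown sits.

Compound 4 `COc1ccc(NC(=O)COc2ccc3c(=O)cc(-c4ccccc4)oc3c2)cc1` stands to compound 3 exactly as compound 2 stands to compound 1: the change is methoxy in place of fluoro on an aromatic carbon, and the surroundings of the place read the same in both pairs, so it is the same change made on the second core. The expectation for compound 4 rests on two facts: the step of a 1.7-fold lower number from compound 1 to compound 2 (0.24 log units; within the scatter) stayed within the scatter, and compound 3 is known only as a limit. Compound 4 is accordingly expected to sit near the limit of this assay, at about 10000 nM, most likely between 4500 nM and 30000 nM. The expected step is thus a number no higher from compound 3 to compound 4 (the limit leaves the size open), essentially flat, with a good chance that the assay again reports only a limit.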

Compound 4, concentration for 50% growth inhibition: 5970 nM
For compound 4 the middle estimate is 1.7-fold (0.22 log units) above the measured one; low and high end bracket the measured number.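

Carried to the core of compound 3, the change from fluoro to methoxy gives an at least 1.6-fold lower number from compound 3 to compound 4 (0.22 log units; that floor lies within the scatter) in this assay. Set beside the step on the core of compound 1, this result fits the change behaving alike on the two cores, but it does not establish that it does, and the numbers do not set the two steps apart: the same change on two cores in this assay, a 1.7-fold lower number (0.24 log units; within the scatter) from compound 1 to compound 2 and an at least 1.6-fold lower number (0.22 log units; that floor lies within the scatter) from compound 3 to compound 4; the limit leaves it open whether they differ

The step on the second core has only a floor and no size of its own, so it is not shown whether the change stays within the scatter there or goes beyond it, because compound 3 stands at a limit and not at a number: the limit of > 10000 nM in this assay, at which 1 of the 4 values shown sits.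

The compounds shown leave open how other groups on that aromatic carbon, such as chloro, a nitrile, an amine or a carboxylic acid, would read in this assay on either core, so two pairs are all that speak for the change from fluoro to methoxy. They also leave open whether a longer chain between the ether oxygen and the amide would alter the picture on either core.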